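The compounds below may be only part of what the source reports. "The series", "measured", "known", "first", "only" and "open" are said of these compounds alone.

Compounds measured in an ADME assay on the whole organism for inhibition, with Oryza sativa as the target, with a stated time of 4 days; a lower number here means a stronger inhibitor, a higher number a weaker inhibitor:
compound 1, `CC(C)Nc1nc(Cl)nc(N[C@@H](C)c2ccccc2)n1`, 23400 nM
compound 2, `CC(C)N(c1nc(Cl)nc(N[C@H](C)c2ccccc2)n1)C(C)C`, 1620 nM
compound 3, `CC(C)N(c1nc(Cl)nc(N[C@@H](C)c2ccccc2)n1)C(C)C`, 372 nM

Among these three numbers compound 2 holds the second highest; its nearest neighbour is compound 3, reached by a 4.4-fold lower number from compound 2 to compound 3 (0.64 log units; beyond the scatter), and its furthest is compound 1. Compounds 2 and 3 share all atoms and bonds, and the fact that compounds 2 and 3 differ only in the configuration as drawn is their only difference. Compound 4, `CNc1nc(Cl)nc(N[C@H](C)c2ccccc2)n1`, differs from compound 2 in one place: methylamino in place of diisopropylamino on an aromatic carbon. The measured step that bears on this change is a 63-fold lower number from compound 1 to compound 3 (1.80 log units; beyond the scatter), where isopropyl in place of hydrogen on a nitrogen on an aromatic ring gave a large drop. Because a 63-fold lower number from compound 1 to compound 3 (1.80 log units; beyond the scatter) ran in that direction, compound 4, which loses substitution on the corresponding nitrogen, is expected to show a large rise, a 31-fold higher number from compound 2 to compound 4 (1.49 log units; beyond the scatter). Compound 4 is therefore estimated at 50000 nM, with a range from 10000 nM to 250000 nM.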

Compound 4, half-maximal inhibitory concentration: 22400 nM
Compound 4: the middle estimate sits 2.2-fold (0.35 log units) above what was measured; measured number inside the range.
By their numbers in this assay, from the lowest: compound 3; then compound 2; then compounds 4 and 1 (each within the scatter of the next).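

Replacing diisopropylamino with methylamino on this aromatic carbon gives a 14-fold higher number from compound 2 to compound 4 (1.14 log units; beyond the scatter), so the loss of substitution on this nitrogen now has a measured cost with the stereocentre drawn R, where the earlier step had it drawn S only. The change also swaps a group without a hydrogen-bond donor for one with a hydrogen-bond donor, so group size and donor count move together here. Nothing shown accounts for the size of this step. From the compounds shown here alone, whether dimethylamino or piperidinyl at this position would behave like diisopropylamino or like methylamino remains open.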